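Chlorination step on a purine-like core: compound 4 estimate

The compounds below may be only part of what the source reports. "The series", "measured", "known", "first", "only" and "open" are said of these compounds alone.

Measured compounds:
- compound 1 `ClCc1ccc(Cn2cnc3c(Cl)ncnc32)cc1`: 3540 nM
- compound 2 `ClCc1cccc(Cn2cnc3ncnc(Cl)c32)c1`: 3230 nM
- compound 3 `ClCc1ccc(Cn2cnc3c(Cl)nc(Cl)nc32)cc1`: 4370 nM

All three were run in a functional assay on OVCAR-3 cells (Homo sapiens) for cytotoxicity, read by sulforhodamine B assay, with a stated time of 48 h; on this read-out higher numbers stand for weaker inhibition of growth and lower numbers for stronger inhibition of growth. Compound 1 gives 3540 nM in this assay, compound 2 gives 3230 nM and compound 3 gives 4370 nM; the three values lie within the scatter of one another, so no order among them is read.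

Compound 3 arises from compound 1 by chloro in place of hydrogen on an aromatic carbon and the step is a 1.2-fold higher number from compound 1 to compound 3 (0.09 log units; within the scatter). Compound 1 and compound 2 have the same atoms joined differently; the difference between the two cores is not broken down here.

Compound 4 `ClCc1cccc(Cn2cnc3nc(Cl)nc(Cl)c32)c1` is not yet measured. It arises from compound 2 by chloro in place of hydrogen on an aromatic carbon, the same change that carries compound 1 to compound 3, at a place described in the same words. The expectation rests on that step: since a 1.2-fold higher number from compound 1 to compound 3 (0.09 log units; within the scatter) stayed within the scatter, compound 4 is expected to stay close to compound 2 in this assay, with an estimated step of a 1.2-fold higher number from compound 2 to compound 4 (0.08 log units; within the scatter). Compound 4 is therefore estimated at 3900 nM, expected to fall between 2000 nM and 7500 nM.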

Compound 4, concentration for total growth inhibition: 2880 nM
Estimate against measurement, compound 4: 1.4-fold (0.13 log units) above, and the stated range covers the measured number.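

In this assay the chloro in place of hydrogen on an aromatic carbon gives a 1.1-fold lower number from compound 2 to compound 4 (0.05 log units; within the scatter) on the second core, and set beside the earlier step, the change carries over without a readable difference: the same change on two cores in this assay, a 1.2-fold higher number (0.09 log units; within the scatter) from compound 1 to compound 3 and a 1.1-fold lower number (0.05 log units; within the scatter) from compound 2 to compound 4, 1.4-fold (0.14 log units) apart, within the scatter of two such steps.

What carries over is only the absence of a step beyond the scatter on either core, so the two steps agree without showing a shared direction, and their opposite signs carry no meaning. With two cores and a single cell read-out, this does not show that the change would stay as small on any other core or in any other assay.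

Left open is whether a group other than chloro at this place, such as an amine or a methoxy group, would move the number beyond the scatter. Also open, as far as these compounds go, is what a longer chain in place of the chloromethyl group would do on either core.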